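A Methoxy for a Fluoro on the Benzylic Ring

A few compounds are considered here, and "the series" means these few. Any claim that something is new, unique, unknown or untested is made for them only; others in the source may bear on it.

Compound 2, `N=C(NCc1ccc(O)cc1)[C@@H]1CCC(=O)N1Cc1ccc(F)cc1`, is the stronger of the two measured compounds in a functional assay on SH-SY5Y cells (Homo sapiens) for cytotoxicity, read by MTT assay, with stated times of 8 h, 30 min and 12 h, tested at 5 uM; a lower number here means a weaker effect, a higher number a stronger effect of the compound at the concentration tested: compound 2 gives 48.6%, whereas compound 1, `N=C(NCc1ccc(O)cc1)[C@@H]1CCC(=O)N1Cc1ccccc1[N+](=O)[O-]`, gives 30.4%. Among the compounds with values here, the single measured step, a number 18.2 percentage points higher from compound 1 to compound 2 (beyond the scatter), lies beyond the scatter, and on these two numbers compound 2 stands highest.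

Compound 3, `COc1ccc(CN2C(=O)CC[C@H]2C(=N)NCc2ccc(O)cc2)cc1`, differs from compound 2 in one place: methoxy in place of fluoro on an aromatic carbon. Within the data shown here, the only step measured so far exchanges a 2-nitrophenyl for a 4-fluorophenyl, a different change from the one at hand; it shows that a change to this group can move the read-out by a modest amount, but it says nothing directly about a methoxy in place of a fluoro. Among the measured compounds shown here, no measured pair isolates that exchange. The step is therefore expected to be small, a number 3.6 percentage points lower from compound 2 to compound 3 (within the scatter), most likely within the scatter in either direction. For compound 3 the estimated value in this assay is 45%, with a range from 25% to 65%.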

Compound 3, a percentage reported as activity, at one concentration (the size of the read-out at that concentration, not a potency): 26.6%
Compound 3: middle estimate off by 18.4 percentage points, on the high side, within the range that was stated.
By their numbers in this assay, from the lowest: compounds 3 and 1 (each within the scatter of the next); then compound 2.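

In this assay, within the data shown here, exchanging fluoro for methoxy on this aromatic carbon, para to a large group, is not a silent change: the pair gives a number 22 percentage points lower from compound 2 to compound 3 (beyond the scatter) and so provides the first measured step that isolates this exchange. The 4-methoxyphenyl and 2-nitrophenyl groups, by contrast, cannot be told apart here, with a number 3.8 percentage points lower from compound 1 to compound 3 (within the scatter) on the shared core, so that among the three compounds only the 4-fluorophenyl of compound 2 stands apart, its steps to both others lying beyond the scatter. Nothing at hand bears on the reason for this separation.

The compounds shown leave open whether the higher read-out belongs to fluoro specifically, and what a chloro, a hydroxyl, an amine or a carboxylic acid on the same aromatic carbon would give. They also leave open whether the 4-fluorophenyl keeps its standing when the rest of the molecule changes, for instance when the 4-hydroxybenzyl group on the other side of the core gives way to a longer chain.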